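Swapping the Halogenated Phenyl on Compound 3

This account rests on a few compounds, and the source may have more. Where it says the series, first, only, none or still open, it means among the compounds named here.

Of the compounds shown here, three built on a shared core have been measured in a functional assay on MCF7 cells (Homo sapiens) for cytotoxicity, read by MTT assay, with a stated time of 72 h; a higher number here means a weaker inhibitor, a lower number a stronger inhibitor. Compound 1 `Cc1cc(=O)n(-c2ccc(Br)cc2F)nc1C(=O)Nc1ccc(Oc2ncnc3ccsc23)cc1` gives 9360 nM; compound 2 `Cc1cc(=O)n(-c2cccc(F)c2)nc1C(=O)Nc1ccc(Oc2ncnc3ccsc23)cc1` gives 6410 nM; compound 3 `Cc1cc(=O)n(-c2ccc(Br)cc2F)nc1C(=O)Nc1ccc(Oc2ncnc3sccc23)cc1` gives 15200 nM. Compound 3 has the highest of the three numbers: its nearest neighbour is compound 1, and that gap lies within the scatter, while the gap to compound 2 lies beyond it. Compound 4 `Cc1cc(=O)n(-c2cccc(F)c2)nc1C(=O)Nc1ccc(Oc2ncnc3sccc23)cc1` carries 3-fluorophenyl in place of 4-bromo-2-fluorophenyl on an aromatic nitrogen. The same change has been measured once before, as a 1.5-fold lower number from compound 1 to compound 2 (0.16 log units; within the scatter), and the difference on the oxygen on the aromatic ring between compound 1 and compound 3 is a 1.6-fold higher number from compound 1 to compound 3 (0.21 log units; within the scatter). Because the step of a 1.5-fold lower number from compound 1 to compound 2 (0.16 log units; within the scatter) stayed within the scatter, no step beyond the scatter is expected for compound 4 either, with the number perhaps settling slightly lower. Compound 4 is therefore expected to give 10000 nM, between 4500 nM and 22000 nM, corresponding to an expected 1.5-fold lower number from compound 3 to compound 4 (0.18 log units; within the scatter).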

Compound 4, half-maximal inhibitory concentration: 27200 nM
For compound 4 the middle estimate is 2.7-fold (0.43 log units) below the measured one, outside the stated range (above it).
By their numbers in this assay, from the lowest: compounds 2, 1, 3 and 4 (each within the scatter of the next, the first and the last beyond it).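

In this assay, the change from 4-bromo-2-fluorophenyl to 3-fluorophenyl on the aromatic nitrogen has now been read on a second core, where it gives a 1.8-fold higher number from compound 3 to compound 4 (0.25 log units; within the scatter), so on neither core does this swap move the number beyond the scatter: the same change on two cores in this assay, a 1.5-fold lower number (0.16 log units; within the scatter) from compound 1 to compound 2 and a 1.8-fold higher number (0.25 log units; within the scatter) from compound 3 to compound 4, 2.6-fold (0.42 log units) apart, within the scatter of two such steps. The exchange of the group on the oxygen, read with 3-fluorophenyl in place, gives a 4.2-fold higher number from compound 2 to compound 4 (0.63 log units; beyond the scatter), which lies beyond the scatter, unlike the reading with 4-bromo-2-fluorophenyl, yet the two readings do not separate from each other: the same change on two cores in this assay, a 1.6-fold higher number (0.21 log units; within the scatter) from compound 1 to compound 3 and a 4.2-fold higher number (0.63 log units; beyond the scatter) from compound 2 to compound 4, 2.6-fold (0.42 log units) apart, within the scatter of two such steps. These four compounds therefore give no firm sign that the two changes depend on each other.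

Going by these compounds, it remains open whether a group without halogen on that aromatic nitrogen, such as a plain phenyl or a butyl chain, would shift the number beyond the scatter. On these data alone, it also remains open whether the gap between compound 2 and compound 4 would hold in a different assay.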